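Swapping bromo for methoxy on a thiazolylidene hydrazide

A few compounds are considered here, and "the series" means these few. Any claim that something is new, unique, unknown or untested is made for them only; others in the source may bear on it.

Three compounds share one core and were tested in a functional assay on C6 cells (Rattus norvegicus) for cytotoxicity, read by MTT assay, with a stated time of 24 h, tested at 12 ug/mL; a lower number here means a stronger effect, a higher number a weaker effect of the compound at the concentration tested. Compound 1 `O=C(CSc1nnnn1-c1ccccc1)N/N=c1/scc(-c2ccc(Br)cc2)n1-c1ccccc1` gives 58.6%. Compound 2 `Cc1ccc(-c2cs/c(=N/NC(=O)CSc3nnnn3C)n2-c2ccccc2)cc1` gives 68.8%. Compound 3 `O=C(CSc1ncccn1)N/N=c1/scc(-c2ccc(Br)cc2)n1-c1ccccc1` gives 72.1%, the highest of the three numbers; compound 2 sits within the scatter of it, while compound 1 lies beyond the scatter, as the step of a number 13.5 percentage points higher from compound 1 to compound 3 (beyond the scatter) shows, where pyrimidin-2-yl replaces 1-phenyl-1H-tetrazol-5-yl on a sulfur.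

Compound 4 `COc1ccc(-c2cs/c(=N/NC(=O)CSc3ncccn3)n2-c2ccccc2)cc1` is not yet measured. It differs from compound 3 in one place: methoxy in place of bromo on an aromatic carbon. Among the compounds with values here, no measured pair differs only in this way, so the one step that is known, the change on the sulfur from compound 1 to compound 3, does not bear on it. With nothing in the measured steps pointing either way, compound 4 is expected to stay close to compound 3, with a step of a number 0.1 percentage points lower from compound 3 to compound 4 (within the scatter) that is not expected to go beyond the scatter. The estimate for compound 4 in this assay is therefore 72%, between 60% and 84%.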

Compound 4, a percentage reported as activity, at one concentration (the size of the read-out at that concentration, not a potency): 78.4%
Beside the measured number, compound 4's estimate is 6.4 percentage points below it, within the range that was stated.
By their numbers in this assay, from the lowest: compound 1; then compounds 2, 3 and 4 (each within the scatter of the next).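

Within the data shown here, compound 3 and compound 4 give the first direct reading of the change from 4-bromophenyl to 4-methoxyphenyl: in this assay it gives a number 6.3 percentage points higher from compound 3 to compound 4 (within the scatter) and so cannot be told apart from repeat measurement. At this place, para to a large group, the single bromine atom can therefore give way to the two heavy atoms of methoxy, with its hydrogen-bond acceptor, without a clear shift in the read-out. No measurement is available that would help to interpret this result.

The compounds shown leave open whether the same swap would also stay within the scatter with 1-phenyl-1H-tetrazol-5-yl on the sulfur, as in compound 1. They also leave open how an amine or a carboxylic acid would read at this same place.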